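The source may hold more compounds than are shown below. What is called first, only, known or untested is meant among the compounds shown, and "the series" means these compounds.

Measured compounds:
compound 1, `COc1ccc(CCC(=O)c2cccc(O)c2)cc1`, 94.5%
compound 2, `COc1ccc(CCC(=O)c2cccc(O)c2)c(OC)c1`, 88.8%
compound 3, `COc1ccc(C(=O)/C=C/c2ccc(OC)c(OC)c2OC)c(O)c1`, 72.5%

The three measured compounds were tested in an ADME assay on RAW264.7 cells (Mus musculus) for cytotoxicity, read by MTT assay, with a stated time of 24 h, tested at 5 ug/mL; a higher number here means a weaker effect of the compound at the concentration tested, a lower number a stronger effect. Compound 1 gives 94.5%, compound 2 gives 88.8% and compound 3 gives 72.5%. Compound 3 stands lowest of the three: against compound 2 its number lies beyond the scatter, and against compound 1 further still.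

Compound 1 and compound 2 share a core and differ in one place, (hydrogen in place of methoxy on an aromatic carbon). That change produced a number 5.7 percentage points higher from compound 2 to compound 1 (within the scatter) in this assay. How the core of compound 3 differs from that of compound 2 is not broken down here.

Compound 4, `COc1ccc(C(=O)/C=C/c2cccc(OC)c2OC)c(O)c1`, has not yet been measured. It differs from compound 3 by hydrogen in place of methoxy on an aromatic carbon. This is the same kind of change as between compound 2 and compound 1, though not the same: in compound 3 the carbon that loses its methoxy is ortho to a methoxy group, meta to a methoxy group and para to a large group, whereas in compound 2 it is ortho to a large group and meta to a methoxy group.

For the measured compounds named here, since the one measured example of this change stayed within the scatter, compound 4 is expected to move little from compound 3, with an estimated step of a number 4.5 percentage points higher from compound 3 to compound 4 (within the scatter) in this assay. Compound 4 is accordingly estimated at 77%, between 62% and 92%, because compound 3 gives 72.5% and the analogous earlier step was a number 5.7 percentage points higher from compound 2 to compound 1 (within the scatter).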

Compound 4, a percentage reported as activity, at one concentration (the size of the read-out at that concentration, not a potency): 69.7%
Compound 4: middle estimate off by 7.3 percentage points, on the high side, and the stated range covers the measured number.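

Taking hydrogen in place of methoxy on an aromatic carbon gave a number 2.8 percentage points lower from compound 3 to compound 4 (within the scatter) in this assay, so on the core of compound 3, as on the core of compound 2, the change left no effect that can be told from the scatter. Set side by side, the two cases show no difference between the cores: the same change on two cores in this assay, a number 5.7 percentage points higher (within the scatter) from compound 2 to compound 1 and a number 2.8 percentage points lower (within the scatter) from compound 3 to compound 4, 8.5 percentage points apart, within the scatter of two such steps. For the compounds shown here, this shows only that the change had little effect in these two cases at the one concentration tested; it does not show that the change would stay as small on a third core, and with both steps inside the scatter, their opposite signs carry no meaning, while the carbon that loses its methoxy also has different surroundings in the two cores.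

The compounds shown leave open what a group other than methoxy or hydrogen would do at this carbon, such as an amine, a carboxylic acid, a fluorine atom or a longer chain like ethoxy. They also leave open whether the step would remain this small at any other concentration in this assay.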